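Swapping the aryl group in a thioether-ring analog

The compounds below may be only part of what the source reports. "The series", "measured", "known", "first", "only" and "open" are said of these compounds alone.

Measured so far:
compound 1 `NC1=NC2(CCSCC2)N(OCCCOc2ccc(Br)cc2)C(N)=N1` — 740 nM
compound 2 `NC1=NC2(CCOCC2)N(OCCCOc2ccc(Cl)cc2Cl)C(N)=N1` — 70 nM
compound 3 `NC1=NC2(CCOCC2)N(OCCCOc2ccc(Br)cc2)C(N)=N1` — 280 nM

In a functional assay on A549 cells (Homo sapiens) for antiproliferative activity, read by MTT assay, with a stated time of 72 h (on this read-out higher numbers stand for weaker inhibition and lower numbers for stronger inhibition), compound 1 gives the highest of the three numbers. Its nearest neighbour is compound 3, which shares the 4-bromophenyl group but carries an oxygen rather than a sulfur in the saturated ring, and compound 3 gives 280 nM; compound 2 gives 70 nM, the lowest of the set.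

Compound 4 `NC1=NC2(CCSCC2)N(OCCCOc2ccc(Cl)c(Cl)c2)C(N)=N1` keeps the core of compound 1 and changes only the aryl group: 3,4-dichlorophenyl in place of 4-bromophenyl on an oxygen on a saturated carbon. Going by the values given here, the one measured step that bears on this change runs in the oxygen series, where a 4.0-fold higher number from compound 2 to compound 3 (0.60 log units; beyond the scatter). That step concerns 2,4-dichlorophenyl rather than 3,4-dichlorophenyl, so it is only a partial guide, but it points toward a lower number when a dichlorophenyl replaces 4-bromophenyl. Compound 4 is therefore expected to give 250 nM, with a likely range from 80 nM to 700 nM; this expectation corresponds to a 3.0-fold lower number from compound 1 to compound 4 (0.47 log units; beyond the scatter), a step toward stronger inhibition in this assay, though smaller than the measured one. Among the compounds with values here, no measured step covers the 3,4-dichlorophenyl pattern itself, so the expectation is held back accordingly.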

Compound 4, half-maximal inhibitory concentration: 1 nM
Compound 4: middle estimate off by 250-fold (2.40 log units), on the high side, outside the stated range (below it).
By their numbers in this assay, from the lowest: compound 4; then compound 2; then compound 3; then compound 1.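

Going by these compounds alone, with only the aryl group changed on the core of compound 1, 3,4-dichlorophenyl in place of 4-bromophenyl gives a 740-fold lower number from compound 1 to compound 4 (2.87 log units; beyond the scatter) in this assay, so this position can move the read-out far more than the earlier compounds showed. Within the data shown here, the only earlier step at this position, a 4.0-fold higher number from compound 2 to compound 3 (0.60 log units; beyond the scatter) on a different core and with 2,4-dichlorophenyl, gave no sign of a change of this size, although both steps agree that the dichlorophenyl compound has the lower number. Nothing available here accounts for the size of the new step.

The compounds shown leave open how 3,4-dichlorophenyl reads with the oxygen in the saturated ring, and so whether this large step depends on the sulfur. They also leave open how a 3-chlorophenyl or 4-chlorophenyl group, or a longer chain, would read.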